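This account rests on a few compounds, and the source may have more. Where it says the series, first, only, none or still open, it means among the compounds named here.

In a functional assay on HeLa cells (Homo sapiens) for cytotoxicity, read by MTT assay, with a stated time of 48 h (on this read-out higher numbers stand for weaker inhibition and lower numbers for stronger inhibition), compound 1 (`COc1ccc(-c2nc3ccccn3c2C(=O)/C=C\Nc2ccc3[nH]ccc3c2)cc1`) gives 13600 nM, compound 2 (`O=C(/C=C\Nc1cnc2ccccc2c1)c1c(-c2ccccc2)nc2ccccn12`) gives 3080 nM and compound 3 (`O=C(/C=C\Nc1ccc2[nH]ccc2c1)c1c(-c2ccc(Cl)cc2)nc2ccccn12`) gives 3240 nM. Compound 3 thus lies within the scatter of compound 2, and both numbers are lower than that of compound 1.

Compound 4 (`O=C(/C=C\Nc1ccc2ncccc2c1)c1c(-c2ccc(Cl)cc2)nc2ccccn12`) differs from compound 3 in one place, with quinolin-6-yl in place of 1H-indol-5-yl on an amine nitrogen.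

Within the data shown here, the only measured step that changes a single place is a 4.2-fold lower number from compound 1 to compound 3 (0.62 log units; beyond the scatter). That modest step put chloro in place of methoxy on an aromatic carbon, so it says nothing directly about this new change. Compound 2, at 3080 nM, lacks the 1H-indol-5-yl group, yet its number lies within the scatter of that of compound 3, although the two also differ elsewhere. This is thin evidence, but it gives no reason to expect a clear move in either direction. The expected size is a 1.0-fold lower number from compound 3 to compound 4 (0.01 log units; within the scatter), which means no change beyond the scatter is anticipated. For compound 4 the estimated value is 3200 nM, with an expected range from 1200 nM to 8500 nM.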

Compound 4, half-maximal inhibitory concentration: 16400 nM
For compound 4 the middle estimate is 5.1-fold (0.71 log units) below the measured one, outside the stated range (above it).
By their numbers in this assay, from the lowest: compounds 2 and 3 (each within the scatter of the next); then compounds 1 and 4 (each within the scatter of the next).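

In this assay, the group on the amine nitrogen proves to matter: with the rest of the molecule unchanged, the swap gives a 5.1-fold higher number from compound 3 to compound 4 (0.70 log units; beyond the scatter), the first single change seen at this place and one that weakens inhibition. The earlier step, a 4.2-fold lower number from compound 1 to compound 3 (0.62 log units; beyond the scatter), changed an aromatic carbon and went the other way, so both places can shift the number. The swap removes a hydrogen-bond donor, adds a hydrogen-bond acceptor and enlarges the group, but no measured evidence shows which of these differences, if any, accounts for the result.

As far as these compounds go, it remains open whether a plain phenyl or a benzyl group on the amine nitrogen would behave more like 1H-indol-5-yl or quinolin-6-yl. From the compounds shown here alone, it is also open whether this step would have the same size with methoxy in place of chloro.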